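Chlorine on the benzylsulfanyl arm of the shared core

A few compounds are considered here, and "the series" means these few. Any claim that something is new, unique, unknown or untested is made for them only; others in the source may bear on it.

Compound 1 `CC1=C(C(=O)Nc2ccc(Br)cc2)C(c2ccc(Cl)cc2Cl)N=C(SCc2ccccc2)N1` is the reference for this arm of the series; in a functional assay on the whole organism (artery, strain albino) with Rattus norvegicus as the target, with a stated time of 180 min, at a dose of 10 mg/kg by the oral route (a higher number here means more inhibition at the dose given (going by the name of the read-out), a lower number less inhibition), compound 1 gives 13.4%. Compound 2 `CC1=C(C(=O)Nc2ccc(Br)cc2)C(c2ccc(Cl)cc2Cl)N=C(SCc2ccc(Cl)cc2)N1` differs from compound 1 by chloro in place of hydrogen on an aromatic carbon, and in this assay compound 2 gives 23.2%. The step of a number 9.8 percentage points higher from compound 1 to compound 2 (within the scatter); the two numbers therefore do not separate.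

Compound 3 `CC1=C(C(=O)Nc2ccc([N+](=O)[O-])cc2)C(c2ccc(Br)cc2)N=C(SCc2ccccc2)N1` belongs to a second core; the difference between the cores of compound 1 and compound 3 is not broken down here. In this assay compound 3 gives 19.6%, which stands near the number for compound 2 and within the usual scatter of the number for compound 1, so no ordering among the three is drawn.

Compound 4 `CC1=C(C(=O)Nc2ccc([N+](=O)[O-])cc2)C(c2ccc(Br)cc2)N=C(SCc2ccccc2Cl)N1` has not been measured. It differs from compound 3 by chloro in place of hydrogen on an aromatic carbon. This is the same kind of change as that from compound 1 to compound 2, not the same one: in compound 2 the chloro sits para to a large group, whereas in compound 4 it sits ortho to a large group. Among the measured compounds shown here, the only measured precedent is a number 9.8 percentage points higher from compound 1 to compound 2 (within the scatter), a step that lies within the scatter, and there is no measured pair for an entering chloro ortho to a large group.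

The step expected from compound 3 to compound 4 is a number 5.4 percentage points higher from compound 3 to compound 4 (within the scatter), resting on the precedent a number 9.8 percentage points higher from compound 1 to compound 2 (within the scatter) and taken as small because a number 9.8 percentage points higher from compound 1 to compound 2 (within the scatter) lies within the scatter. For compound 4 in this assay a value of 25% is estimated, expected to fall between 8% and 42%.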

Compound 4, a percentage reported as inhibition, in the whole organism at one dose (the size of the read-out at that dose, not a potency): 11.3%
Compound 4: the middle estimate sits 13.7 percentage points above what was measured, and the stated range covers the measured number.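

Carrying this change across cores

In this assay the new step reads a number 8.3 percentage points lower from compound 3 to compound 4 (within the scatter) and, taken alone, does not separate compound 4 from compound 3. Set beside the earlier step, however, chloro in place of hydrogen on an aromatic carbon does not carry from one core to the other as a fixed increment: the same change on two cores in this assay, a number 9.8 percentage points higher (within the scatter) from compound 1 to compound 2 and a number 8.3 percentage points lower (within the scatter) from compound 3 to compound 4, 18.1 percentage points apart, beyond the scatter of two such steps

This does not show whether the core or the place of the chloro accounts for the gap, since the two pairs differ in both: the entering chloro is ortho to a large group in compound 4 but not in compound 2, and the core of compound 1 is not the core of compound 3. The step from one core therefore gives no usable estimate for the other here, and neither pair on its own establishes that the chloro raises or lowers the read-out.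

The compounds shown leave open what the 2-chlorobenzyl group does on the core of compound 1, and what the chloro of compound 2 does in its own place on the core of compound 3. They also leave open how the benzylsulfanyl arm would respond to an amine or a carboxylic acid on its ring, or to a longer chain in place of the benzyl.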